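The compounds below may be only part of what the source reports. "The series", "measured", "known", "first", "only" and "open" are said of these compounds alone.

In an assay on isolated protein for inhibition of DNA topoisomerase 1 (Homo sapiens), tested at 100 uM (a higher number here means a stronger effect of the compound at the concentration tested, a lower number a weaker effect), compound 1 `Clc1ccc(-c2cc(-c3ccsc3)nc(-c3ccccc3Cl)c2)o1` gives 0%, compound 2 `Clc1ccc(-c2cc(-c3cccnc3)nc(-c3cccs3)c2)o1` gives 25.8%, and compound 3 `Clc1ccc(-c2cc(-c3ccco3)nc(-c3cccs3)c2)o1` gives 16%. Among the compounds with values here, the single measured step, a number 9.8 percentage points lower from compound 2 to compound 3 (within the scatter), lies within the scatter. Compound 3 thus stands second highest of the three numbers, nearest to compound 2 and separated from compound 1 by a gap beyond the scatter. Compound 4 `Clc1ccc(-c2cc(-c3cccs3)nc(-c3ccccc3Cl)c2)o1` differs from compound 3 by 2-chlorophenyl in place of furan-2-yl on an aromatic carbon. Within the data shown here, no measured step covers this exchange; the only bearing is that compound 1, which also carries a 2-chlorophenyl group, gives 0%, whereas compound 3 gives 16%. A downward step beyond the scatter is therefore expected, a number 11 percentage points lower from compound 3 to compound 4 (beyond the scatter). For compound 4 the estimate in this assay is 5%, within 0% to 20%.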

Compound 4, a percentage reported as inhibition, at one concentration (the size of the read-out at that concentration, not a potency): 41.3%
Compound 4: middle estimate off by 36.3 percentage points, on the low side, and the stated range ends below it.
By their numbers in this assay, from the lowest: compound 1; then compounds 3 and 2 (each within the scatter of the next); then compound 4.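

In this assay, 2-chlorophenyl next to the ring nitrogen is not a low-value group in itself: replacing furan-2-yl gives a number 25.3 percentage points higher from compound 3 to compound 4 (beyond the scatter) and replacing pyridin-3-yl gives a number 15.5 percentage points higher from compound 2 to compound 4 (beyond the scatter) as the result of the same exchange. The reading of the 2-chlorophenyl compound 1 (0%) does not carry over, since thiophen-2-yl in place of thiophen-3-yl gives a number 41.3 percentage points higher from compound 1 to compound 4 (beyond the scatter), so the thiophene attachment weighs heavily in this pair. No evidence at hand accounts for these steps.

On these data alone, whether the thiophene attachment has the same weight alongside furan-2-yl or pyridin-3-yl remains open. Also open, as far as these compounds go, is how a carboxylic acid or an amine on the phenyl ring would read here.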